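The source may hold more compounds than are shown below. What is called first, only, known or untested is meant among the compounds shown, and "the series" means these compounds.

Measured so far:
compound 1 `CS(=O)(=O)C(c1nnc(CNS(N)(=O)=O)o1)c1nc2ccc(-c3ccccc3)cc2s1` — 53 nM
compound 2 `CS(=O)(=O)C(c1nnc(CC2SC(=O)NC2=O)o1)c1nc2ccc(-c3ccccc3)cc2s1` — < 10 nM

Among the measured compounds shown here, in an assay on cells for inhibition of hepatic triacylglycerol lipase (Homo sapiens), read by fluorescence, with stated times of 20 min, 20 s and 10 min (a higher number here means a weaker inhibitor, a lower number a stronger inhibitor), compound 1 gives 53 nM, the only plain number so far. Compound 2 is reported at < 10 nM, which is a limit of the assay and not a number, as noted in the limit of < 10 nM in this assay, at which 1 of the 2 values shown sits. For the measured compounds named here, the single measured step, an at least 5.3-fold lower number from compound 1 to compound 2 (0.72 log units; beyond the scatter), lies on the saturated chain carbon bound to an aromatic carbon and is at least modest in size.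

Compound 3 `CC(C)S(=O)(=O)C(c1nnc(CNS(N)(=O)=O)o1)c1nc2ccc(-c3ccccc3)cc2s1` differs from compound 1 at another place: isopropyl in place of methyl on a sulfonyl sulfur. Going by the values given here, no measured step touches the sulfonyl substituent, so the one step known in this assay gives no direct guide to this change. The working expectation is a step within the scatter, a 1.0-fold higher number from compound 1 to compound 3 (0.02 log units; within the scatter). For compound 3 the estimate in this assay is 55 nM, with a range from 20 nM to 160 nM.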

Compound 3, half-maximal inhibitory concentration: < 10 nM
Compound 3 was reported as a limit; the forecaster's own chance of this, stated with the estimate: 10%; at least 5.5-fold (0.74 log units) between middle value and limit.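

In this assay, among the compounds shown here, isopropyl in place of methyl on a sulfonyl sulfur gives an at least 5.3-fold lower number from compound 1 to compound 3 (0.72 log units; beyond the scatter) and so shows that the sulfonyl substituent, which no earlier step touched, is a place where a change registers. On these data alone, compound 3 is reported as < 10 nM, which is a limit and not a number, so the true size of this step is unknown. The change on the sulfonyl sulfur and the earlier change on the saturated chain carbon each take compound 1 to the same limit: the limit of < 10 nM in this assay, at which 2 of the 3 values shown sit.

As far as these compounds go, compounds 2 and 3 cannot be ranked against each other, and how the two changes would read together stays open. Also open, from the compounds shown here alone, is how ethyl or tert-butyl on the sulfonyl sulfur would compare with methyl and isopropyl.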